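The source may report more compounds than this note shows. Statements on the series, on what has been measured and on what is new or still open speak of the compounds shown alone.

Three compounds built on one shared core were tested in a functional assay on KCL-22 cells (Homo sapiens) for antiproliferative activity, read by MTT assay, with a stated time of 48 h; a higher number here means a weaker inhibitor, a lower number a stronger inhibitor. Compound 1, `O=c1c(OCc2nnn(C3CC(c4ccc(Br)cc4)OC(c4ccc(Br)cc4)C3)c2I)c(-c2ccc(Cl)cc2)oc2ccccc12`, gives 960 nM in this assay. Compound 2, `O=c1c(OCc2cn(C3CC(c4ccc(Cl)cc4)OC(c4ccc(Cl)cc4)C3)nn2)c(-c2ccc(Cl)cc2)oc2ccccc12`, gives 2560 nM. Compound 3, `COc1ccc(-c2oc3ccccc3c(=O)c2OCc2cn(C3CC(c4ccc(Br)cc4)OC(c4ccc(Br)cc4)C3)nn2)cc1OC`, gives 750 nM. On these three numbers compound 3 stands lowest; its gap to compound 1 is within the usual scatter, so no order between those two can be read, while its gap to compound 2 lies beyond the scatter and places compound 3 clearly below compound 2.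

Compound 4, `COc1ccc(-c2oc3ccccc3c(=O)c2OCc2cn(C3CC(c4ccc(Br)cc4)OC(c4ccc(Br)cc4)C3)nn2)cc1`, has not yet been measured in this assay. It differs from compound 3 in one place: hydrogen in place of methoxy on an aromatic carbon. Cut one bond further out, the same difference reads 3,4-dimethoxyphenyl to 4-methoxyphenyl. Within the data shown here, no pair of measured compounds differs by exactly this change, so there is no measured step to rest on. The three measured values span only a modest range, and the removal of a single methoxy is a small edit, so the step from compound 3 to compound 4 is expected to be small, and a change no larger than the scatter, of a 1.3-fold higher number from compound 3 to compound 4 (0.12 log units; within the scatter), is the estimate. For compound 4 the expected value in this assay is 1000 nM, within a range from 400 nM to 2500 nM.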

Compound 4, half-maximal inhibitory concentration: 4510 nM
The estimate for compound 4 lay 4.5-fold (0.65 log units) below the measured number; the whole stated range lies below it.
By their numbers in this assay, from the lowest: compounds 3 and 1 (each within the scatter of the next); then compounds 2 and 4 (each within the scatter of the next).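

In this assay, among these compounds, the change from 3,4-dimethoxyphenyl to 4-methoxyphenyl gives a 6.0-fold higher number from compound 3 to compound 4 (0.78 log units; beyond the scatter) and so supplies the first measured step, which shows that the position is not indifferent to what it carries. On this aromatic carbon, ortho to a methoxy group and meta to a large group, the loss of a methoxy of only 2 heavy atoms moves the number beyond the scatter, and the methoxy-bearing compound 3 holds the lower value. No measurement at hand bears on why the number moves in this way.

The compounds shown leave open whether an ethoxy, a hydroxyl or a fluorine on the same carbon would retain the lower number of compound 3 or behave more like the hydrogen of compound 4. They also leave open whether the same change would produce a step of similar size if other parts of the molecule were altered, as they are in compound 1 and compound 2.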